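The compounds below may be only part of what the source reports. "The series", "measured", "known", "first", "only" and "open" are said of these compounds alone.

Working notes on the series. Compound 1 `O=C(Nc1cccc(-n2cc(-c3ccncc3)c(-c3cc(O)cc(Cl)c3)n2)c1)Nc1ccc(Cl)c(Cl)c1` and compound 2 `COc1cc(Cl)cc(-c2nn(-c3cccc(NC(=O)Nc4ccc(Cl)c(Cl)c4)c3)cc2-c2ccncc2)c1` share one core, and in a functional assay on SN12C cells (Homo sapiens) for inhibition, read by sulforhodamine B assay, with a stated time of 48 h, tested at 0.1 uM (a lower number here means a stronger effect, a higher number a weaker effect of the compound at the concentration tested), compound 1 gives 95%. The step of a number 5 percentage points higher from compound 1 to compound 2 (within the scatter) brings compound 2 to 100%, which is the higher of the two numbers on hand, with compound 1 the nearer of the two and within the scatter of it.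

Compound 3 `COc1cc(Cl)cc(-c2nn(-c3cccc(NC(=O)c4cccc(C(F)(F)F)c4)c3)cc2-c2ccncc2)c1` differs from compound 2 by 3-(trifluoromethyl)phenyl in place of (3,4-dichlorophenyl)amino on a carbonyl carbon. Among the measured compounds shown here, the only measured step, from compound 1 to compound 2, touches the methyl on the oxygen and says nothing about a change on the carbonyl carbon, so no measured step bears on this one; both measured values in this assay sit near the top of the scale.

In the absence of a bearing step, the expected step of a number 5 percentage points lower from compound 2 to compound 3 (within the scatter) is none beyond the scatter. Compound 3 is estimated at 95% in this assay, with a range from 78% to 108%.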

Compound 3, a percentage reported as activity, at one concentration (the size of the read-out at that concentration, not a potency): 99%
Compound 3: the middle estimate sits 4 percentage points below what was measured; measured number inside the range.
By their numbers in this assay, from the lowest: compounds 1, 3 and 2 (each within the scatter of the next).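

In this assay, this first change on the carbonyl carbon gives a number 1 percentage points lower from compound 2 to compound 3 (within the scatter), so the position tolerates 3-(trifluoromethyl)phenyl in place of (3,4-dichlorophenyl)amino without a readable shift, even though the hydrogen-bond donor of the leaving group is absent from the entering one. This is the second place in the series where a change stays within the scatter, after the methyl on the oxygen, and compound 3 at 99% remains near the top of the scale, where a single concentration separates little. No measured evidence explains why the read-out holds across this change.

As far as these compounds go, it remains open whether a different group on the carbonyl carbon, such as a morpholine or a small alkyl chain, would bring the number down. From the compounds shown here alone, it is equally open whether compound 2 and compound 3 would separate at a higher concentration.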